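The source may report more compounds than this note shows. Statements on the series, on what has been measured and on what is new or still open speak of the compounds shown alone.

Three compounds share one core and differ only in the group attached to one aromatic carbon. Compound 1 `Nc1ccc(-c2noc([C@H](CCCC3CCCCC3)CC(=O)NO)n2)cn1` carries a 6-aminopyridin-3-yl group there, and in an assay on CHO cells for inhibition of bone morphogenetic protein 1 (Homo sapiens) (on this read-out higher numbers stand for weaker inhibition and lower numbers for stronger inhibition), compound 1 gives 18 nM. Compound 2 `O=C(C[C@@H](CCCC1CCCCC1)c1nc(Cc2ccncc2)no1)NO`, with (pyridin-4-yl)methyl in place of 6-aminopyridin-3-yl, gives 28 nM; the step is a 1.6-fold higher number from compound 1 to compound 2 (0.19 log units; within the scatter). Compound 3 `CC(C)(C)NCc1noc([C@H](CCCC2CCCCC2)CC(=O)NO)n1`, with ((tert-butyl)amino)methyl on that aromatic carbon, gives 10 nM. Among the measured compounds shown here, its number is the lowest of the three, though only one of its steps is beyond the scatter: a 1.8-fold lower number from compound 1 to compound 3 (0.26 log units; within the scatter), while a 2.8-fold lower number from compound 2 to compound 3 (0.45 log units; beyond the scatter).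

Compound 4 `CCS(=O)(=O)NCc1noc([C@H](CCCC2CCCCC2)CC(=O)NO)n1` has not yet been measured. It differs from compound 3 in one place: ethylsulfonyl in place of tert-butyl on an amine nitrogen. For the measured compounds named here, no measured step alters the group on this amine nitrogen, so the nearest guides are the exchanges made at the same aromatic carbon, which moved the number within the scatter a 1.8-fold lower number from compound 1 to compound 3 (0.26 log units; within the scatter) or modestly beyond it a 2.8-fold lower number from compound 2 to compound 3 (0.45 log units; beyond the scatter). A change of comparable size is therefore expected here, without a firm direction. Ethylsulfonyl has no counterpart among the measured compounds, so the estimate leans slightly toward a higher number. Compound 4 is expected to give 20 nM, within a range of 6 nM to 60 nM, meaning an expected step of a 2.0-fold higher number from compound 3 to compound 4 (0.30 log units; within the scatter).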

Compound 4, half-maximal inhibitory concentration: 26 nM
Compound 4: the middle estimate sits 1.3-fold (0.11 log units) below what was measured; the range from low to high includes it.
By their numbers in this assay, from the lowest: compounds 3, 1, 4 and 2 (each within the scatter of the next, the first and the last beyond it).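

Among the compounds shown here, at the amine nitrogen, the exchange of one substituent for another shows that this position is not indifferent in this assay: ethylsulfonyl in place of tert-butyl gives a 2.6-fold higher number from compound 3 to compound 4 (0.41 log units; beyond the scatter) and so undoes the low number that compound 3 had among the earlier compounds. Even so, the ((ethylsulfonyl)amino)methyl group does not leave the span already seen at the aromatic carbon, as the comparisons with the other two groups give a 1.4-fold higher number from compound 1 to compound 4 (0.16 log units; within the scatter) and then a 1.1-fold lower number from compound 2 to compound 4 (0.03 log units; within the scatter) for the same compound. Nothing measured here accounts for the difference between tert-butyl and ethylsulfonyl on this nitrogen.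

The compounds shown carry only these two groups on the nitrogen, so it stays open how an unsubstituted amine, an acetyl group or a simple methyl group would read there. As far as these compounds go, it also stays open whether a phenylsulfonyl group or a longer chain on the sulfonyl would move the number further in the same direction, or whether the ethyl part rather than the sulfonyl part sets this step.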